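This account rests on a few compounds, and the source may have more. Where it says the series, first, only, none or still open, it means among the compounds named here.

Measured so far in a functional assay on PC-3 cells (Homo sapiens) for cytotoxicity, read by MTT assay; on this read-out lower numbers stand for stronger inhibition and higher numbers for weaker inhibition:
compound 1 `Cc1ccc(Nc2nc(C)c(C(=O)/C=C/c3ccc(Cl)cc3)s2)cc1` — compound 1 gives > 25000 nM, a limit of the assay
compound 2 `Cc1cccc(Nc2nc(C)c(C(=O)/C=C/c3ccc(Cl)cc3)s2)c1` — compound 2 gives > 25000 nM, a limit of the assay
compound 3 `Cc1cccc(Nc2nc(C)c(C(=O)/C=C/c3ccccc3Cl)s2)c1` — compound 3 gives 22200 nM

Compound 2 therefore stands at the limit of this assay and carries no number of its own; it shares that position with compound 1 (the limit of > 25000 nM in this assay, at which 2 of the 3 values shown sit). The step that the two limits leave unreadable from compound 1 to compound 2 is thus not readable. The step of an at least 1.1-fold lower number from compound 2 to compound 3 (0.05 log units; that floor lies within the scatter), from a limit to a number just inside the measurable range, lies within the scatter.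

Compound 4 `Cc1ccccc1Nc1nc(C)c(C(=O)/C=C/c2ccc(Cl)cc2)s1` is the next variation on the same nitrogen: 2-methylphenyl in place of 3-methylphenyl on a nitrogen on an aromatic ring. Among the compounds with values here, the only measured step that bears on it is the one between compound 1 and compound 2, which also moves the methyl around the phenyl on that nitrogen, and it gives no readable size. Nothing in the measured steps points to a change beyond the scatter in this assay, in either direction, and the two neighbours on this nitrogen both sit at the limit.

Compound 4 is accordingly expected to stay near the limit, with an estimate of 30000 nM and a range from 12000 nM to 90000 nM. The expected step that the limit leaves unreadable from compound 2 to compound 4 is essentially none, and a further limit rather than a number is the most likely outcome.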

Compound 4, half-maximal inhibitory concentration: > 25000 nM
Compound 4 ended at the assay's limit; the forecaster's own chance of this, stated with the estimate: 70%; the middle value lies beyond the limit too.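

Compound 4 gives > 25000 nM in this assay, which is a limit and not a number. The steps joining compound 1, compound 2 and compound 4 therefore cannot be read: the limit of > 25000 nM in this assay, at which 3 of the 4 values shown sit.

The compounds shown leave open whether 2-methylphenyl, 3-methylphenyl and 4-methylphenyl on this nitrogen differ at all in this assay.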